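Swapping trifluoromethyl for bromo on a well-tolerated scaffold

The source may report more compounds than this note shows. Statements on the series, on what has been measured and on what is new or still open speak of the compounds shown alone.

Compound 1 `FC(F)(F)c1ccc(NCc2cn(-c3ccccc3)nc2-c2ccc(Br)cc2)cc1` was examined in an ADME assay on MT4 cells (Homo sapiens) for cytotoxicity, read by MTT assay, with a stated time of 96 h; a lower number here means that less compound is tolerated, a higher number that more compound is tolerated. In this assay compound 1 gives > 100000 nM, which is a limit of the assay and not a measured number. Compound 2 `FC(F)(F)c1ccc(NCc2cn(-c3ccccc3)nc2-c2ccc(C(F)(F)F)cc2)cc1` carries trifluoromethyl in place of bromo on an aromatic carbon, and compound 2 gives > 100000 nM, again a limit. Compound 3 `FC(F)(F)c1ccc(NCc2cn(-c3ccccc3)nc2-c2ccccc2)cc1` gives > 100000 nM, also a limit. The steps a step that the two limits leave unreadable from compound 1 to compound 2, a step that the two limits leave unreadable from compound 1 to compound 3 and a step that the two limits leave unreadable from compound 2 to compound 3 therefore cannot be sized; all that can be seen is the limit of > 100000 nM in this assay, at which 3 of the 3 values shown sit.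

Compound 4 `Brc1ccc(NCc2cn(-c3ccccc3)nc2-c2ccc(Br)cc2)cc1` differs from compound 1 by bromo in place of trifluoromethyl on an aromatic carbon. Within the data shown here, no measured step changes this group, and because the limit of > 100000 nM in this assay, at which 3 of the 3 values shown sit, holds every measured compound, no step beyond the scatter in either direction is expected here. Compound 4 is therefore expected to give about 100000 nM, between 50000 nM and 300000 nM, most likely reported once more only as a limit. This estimate means an expected step of a number no higher from compound 1 to compound 4 (the limit leaves the size open), none beyond the scatter.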

Compound 4, half-maximal cytotoxic concentration: > 100000 nM
Compound 4: only a limit was reported; the forecaster's own chance of this, stated with the estimate: 85%; the middle value sits exactly at the limit.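

No size can be read for the change from compound 1 to compound 4, since both compounds sit at the same limit: the limit of > 100000 nM in this assay, at which 4 of the 4 values shown sit. The compounds shown leave open how much of each compound the cells tolerate beyond that limit, and whether the four differ there.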